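A few compounds are considered here, and "the series" means these few. Any claim that something is new, unique, unknown or untested is made for them only; others in the source may bear on it.

Compound 1 `COc1ccc(-c2csc(N/N=C(\C)c3cc4ccccc4o3)n2)cc1` gives 28900 nM in a functional assay on PC-3 cells (Homo sapiens) for antiproliferative activity; on this read-out higher numbers stand for weaker inhibition and lower numbers for stronger inhibition.
Compound 2 `CCOC(=O)Cc1csc(N/N=C(\C)c2cc3ccccc3o2)n1` gives 13100 nM in this assay.

Compound 2 stands as the lower of the two numbers, set apart by a 2.2-fold lower number from compound 1 to compound 2 (0.34 log units; beyond the scatter). Compound 3 `C/C(=N\Nc1nc(-c2cc3ccccc3o2)cs1)c1cc2ccccc2o1` differs from compound 2 by 1-benzofuran-2-yl in place of (ethoxycarbonyl)methyl on an aromatic carbon. Going by the values given here, the only step known at this place is a 2.2-fold lower number from compound 1 to compound 2 (0.34 log units; beyond the scatter), where 4-methoxyphenyl gave way to (ethoxycarbonyl)methyl and the number fell modestly. Compound 3 brings a ring group, 1-benzofuran-2-yl, back to this place, so a modest rise of the number is expected in this assay. Compound 3 is estimated at 25000 nM, within 9000 nM to 70000 nM, an expected step of a 1.9-fold higher number from compound 2 to compound 3 (0.28 log units; within the scatter).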

Compound 3, half-maximal inhibitory concentration: 34200 nM
Compound 3: middle estimate off by 1.4-fold (0.14 log units), on the low side; the measured number falls inside the stated range.
By their numbers in this assay, from the lowest: compound 2; then compounds 1 and 3 (each within the scatter of the next).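

Replacing 4-methoxyphenyl with 1-benzofuran-2-yl gives a 1.2-fold higher number from compound 1 to compound 3 (0.07 log units; within the scatter), so these two ring groups cannot be told apart at this place in this assay. Going by these compounds alone, replacing (ethoxycarbonyl)methyl, the one group here without a ring, with 1-benzofuran-2-yl gives a 2.6-fold higher number from compound 2 to compound 3 (0.42 log units; beyond the scatter), so the lower number of compound 2 now stands against two different ring groups. Nothing measured here explains that difference. On these data alone, it remains open whether the lack of a ring or the ethoxycarbonyl group itself goes with the lower number. A plain methyl, a carboxylic acid or an amine at this place could help separate the two.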